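This account rests on a few compounds, and the source may have more. Where it says the series, first, only, none or still open, it means among the compounds named here.

For the measured compounds named here, compound 2 `CCOC(=O)C1=Cc2ccccc2OC1(OCc1cn(CC(=O)Nc2ccccc2F)nn1)C(F)(F)F` stands second highest of the three numbers so far, though both gaps lie within the scatter: in a functional assay on MCF7 cells (Homo sapiens) for inhibition, read by MTT assay, with a stated time of 24 h (on this read-out higher numbers stand for weaker inhibition and lower numbers for stronger inhibition), compound 2 gives 42100 nM, while compound 1 `O=C(O)C1=Cc2ccccc2OC1(OCc1cc(-c2ccc(F)cc2)no1)C(F)(F)F` gives 64200 nM and compound 3 `COc1ccc(-c2cc(COC3(C(F)(F)F)Oc4ccccc4C=C3C(=O)O)on2)cc1` gives 35200 nM. Compound 4 `CCOC(=O)C1=Cc2ccccc2OC1(OCc1cn(CC(=O)Nc2ccc(OC)cc2)nn1)C(F)(F)F` differs from compound 2 by 4-methoxyphenyl in place of 2-fluorophenyl on an amide-type nitrogen. Going by the values given here, the only measured step of a related kind is a 1.8-fold lower number from compound 1 to compound 3 (0.26 log units; within the scatter), a change from fluoro to methoxy on an aromatic carbon in the core of compound 1, which stayed within the scatter. Among the compounds with values here, no step on the amide side of compound 2 itself has been measured. A step of similar size, or none beyond the scatter, is therefore expected in this assay: a 1.2-fold lower number from compound 2 to compound 4 (0.08 log units; within the scatter). Compound 4 is estimated at 35000 nM, within 14000 nM to 90000 nM.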

Compound 4, half-maximal inhibitory concentration: 28100 nM
Compound 4: middle estimate off by 1.2-fold (0.10 log units), on the high side, and the stated range covers the measured number.
By their numbers in this assay, from the lowest: compounds 4, 3, 2 and 1 (each within the scatter of the next, the first and the last beyond it).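

The first step read on the amide side, from 2-fluorophenyl to 4-methoxyphenyl on the amide-type nitrogen, gives in this assay a 1.5-fold lower number from compound 2 to compound 4 (0.18 log units; within the scatter). So this position tolerates that exchange, including the hydrogen-bond acceptor that enters with 4-methoxyphenyl, without a step beyond the scatter. No measurement is available that bears on this result.

Open, on these data alone, is whether an amine, a carboxylic acid or a longer chain on this nitrogen would move the number beyond the scatter. Plain phenyl is also open, and it would separate the loss of fluoro from the gain of methoxy.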